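Adding a Second Trifluoromethyl to the Amide Ring

The source may hold more compounds than are shown below. What is called first, only, known or untested is meant among the compounds shown, and "the series" means these compounds.

Measured so far:
compound 1 `COc1cc(Cl)cc(-c2nn(-c3cccc(NC(=O)Nc4ccc(Cl)c(C(F)(F)F)c4)c3)cc2-c2ccncc2)c1` gives 9.81%
compound 2 `COc1cc(Cl)cc(-c2nn(-c3cccc(NC(=O)c4cccc(C(F)(F)F)c4)c3)cc2-c2ccncc2)c1` gives 89.5%

In a functional assay on BT-549 cells (Homo sapiens) for inhibition, read by sulforhodamine B assay, with a stated time of 48 h, tested at 10 uM (a lower number here means a stronger effect, a higher number a weaker effect of the compound at the concentration tested), compound 2 gives 89.5%, the higher of the two numbers and thus the weaker effect, while compound 1 gives 9.81%. Going by the values given here, the only measured step, a number 79.7 percentage points higher from compound 1 to compound 2 (beyond the scatter), concerns the group on the carbonyl carbon and shows that a change at this part of the molecule can move the read-out a long way. Compound 3 `COc1cc(Cl)cc(-c2nn(-c3cccc(NC(=O)c4cc(C(F)(F)F)cc(C(F)(F)F)c4)c3)cc2-c2ccncc2)c1` differs from compound 2 by trifluoromethyl in place of hydrogen on an aromatic carbon. Among the compounds with values here, no measured step shows what a second trifluoromethyl on that ring does, so nothing here points toward either direction. From the compounds shown here alone, the expected step is therefore about a number 4.5 percentage points lower from compound 2 to compound 3 (within the scatter) in this assay, within the scatter, with a wide range to allow for what is unknown. Compound 3 is estimated to give 85%, between 55% and 105%.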

Compound 3, a percentage reported as activity, at one concentration (the size of the read-out at that concentration, not a potency): 96.8%
Estimate against measurement, compound 3: 11.8 percentage points below, within the range that was stated.
By their numbers in this assay, from the lowest: compound 1; then compounds 2 and 3 (each within the scatter of the next).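

In this assay, putting trifluoromethyl in place of hydrogen on this aromatic carbon, meta to a trifluoromethyl group, gives a number 7.3 percentage points higher from compound 2 to compound 3 (within the scatter), so compound 2 and compound 3 cannot be told apart. This ring position therefore tolerates the added group without any clear change in the read-out, unlike the large step of a number 79.7 percentage points higher from compound 1 to compound 2 (beyond the scatter) seen on changing the group on the carbonyl carbon. No measurement here explains why the read-out holds steady at this position.

From the compounds shown here alone, it remains open whether a nitrile or an amine on the same carbon would leave the read-out just as unchanged. It is also unknown whether a second trifluoromethyl would behave the same way on the ring of compound 1, whose urea link gives a far stronger effect at 9.81%.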